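From trifluoromethyl to methyl on the shared core

The compounds below may be only part of what the source reports. "The series", "measured", "known", "first", "only" and "open" are said of these compounds alone.

Measured in an ADME assay on THP-1 cells (Homo sapiens) for cytotoxicity, read by MTT assay, with a stated time of 72 h; on this read-out lower numbers stand for stronger inhibition and higher numbers for weaker inhibition:
Compound 1 `COc1cccc(/C=C/C(=O)c2c(O)c3ccccc3[nH]c2=O)c1`: 38500 nM
Compound 2 `O=C(O)c1ccc(/C=C/C(=O)c2c(O)c3ccccc3[nH]c2=O)cc1`: > 50000 nM
Compound 3 `O=C(/C=C/c1ccc(C(F)(F)F)cc1)c1c(O)c2ccccc2[nH]c1=O`: > 50000 nM

Going by the values given here, compound 1 is the only one with a true number. Compound 2 gives only a limit, > 50000 nM. Compound 3 also gives only a limit, > 50000 nM, and so stands at the limit of > 50000 nM in this assay, at which 2 of the 3 values shown sit.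

Compound 4 `Cc1ccc(/C=C/C(=O)c2c(O)c3ccccc3[nH]c2=O)cc1` carries methyl in place of trifluoromethyl on an aromatic carbon, para to a large group: methyl in place of trifluoromethyl on an aromatic carbon. Among the compounds with values here, the one measured step at this place, a step that the two limits leave unreadable from compound 2 to compound 3, has no readable size. No large change is therefore expected in this assay, and the result may again be a limit. The expected change is an at least 1.1-fold lower number from compound 3 to compound 4 (0.04 log units; that floor lies within the scatter). For compound 4 the estimated value is 45000 nM, with an expected range from 22000 nM to 70000 nM.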

Compound 4, half-maximal inhibitory concentration: > 50000 nM
Compound 4: no number, only a limit; the forecaster's own chance of this, stated with the estimate: 50%; middle value at least 1.1-fold (0.04 log units) from the limit.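

In this assay compound 4 gives only a limit, so methyl, like trifluoromethyl and carboxy, yields no true number at this place: the limit of > 50000 nM in this assay, at which 3 of the 4 values shown sit. The steps among the three limit compounds cannot be read. Going by these compounds alone, the only readable step is an at least 1.2-fold higher number from compound 1 to compound 4 (0.11 log units; that floor lies within the scatter), so it gives a floor and no measured size.

On these data alone, how far these three compounds lie beyond the limit stays open. So does whether an amine or a hydroxy group on this aromatic carbon would give a true number on the shared core.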